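The compounds below may be only part of what the source reports. "The series", "measured", "known", "first", "only" and "open" are said of these compounds alone.

Of the compounds shown here, three built on one shared core have been measured in a functional assay on HT-1080 cells (Homo sapiens) for cytotoxicity, read by MTT assay, with a stated time of 72 h; a higher number here means a weaker inhibitor, a lower number a stronger inhibitor: compound 1 `COc1cc(/C=C2\CCC/C(=C\c3cccc(OC)c3OC)C2=O)cc(OC)c1` gives 4500 nM, compound 2 `COc1cccc(/C=C2\CCC/C(=C\c3ccc(O)c(O)c3)C2=O)c1OC` gives 4700 nM, and compound 3 `COc1ccc(/C=C2\CCC/C(=C\c3cccc(Cl)c3)C2=O)cc1OC` gives 4900 nM. These numbers lie within the usual scatter of repeated measurements, so compound 3 stands level with the other two and no ranking can be drawn. Compound 4 `COc1cccc(/C=C2\CCC/C(=C\c3ccc(OC)c(OC)c3)C2=O)c1` has not yet been measured. It differs from compound 3 in one place, a methoxy in place of chloro on an aromatic carbon, meta to a large group: methoxy in place of chloro on an aromatic carbon. Among the measured compounds shown here, no measured pair shows the effect of this single change directly, so the expectation rests on indirect evidence. Compound 1, which also carries methoxy groups, gives 4500 nM, level with compound 3 at 4900 nM. No step beyond the scatter is therefore expected in this assay, and the estimated change, a 1.1-fold lower number from compound 3 to compound 4 (0.03 log units; within the scatter), reflects this. The expected value for compound 4 is 4600 nM, with an estimated range of 2200 nM to 9500 nM.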

Compound 4, half-maximal inhibitory concentration: 4600 nM
The estimate for compound 4 equals the measured number at the digits printed; the measured number falls inside the stated range.
By their numbers in this assay, from the lowest: compounds 1, 4, 2 and 3 (each within the scatter of the next).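

In this assay, the step from chloro to methoxy on this aromatic carbon, meta to a large group, can now be read directly: it is a 1.1-fold lower number from compound 3 to compound 4 (0.03 log units; within the scatter) and so gives no real difference. The earlier compounds shown here stood level too, but none of them differed in only one place, so they could not isolate any single group. This pair does, and it shows that at this position, on this core, methoxy and chloro cannot be told apart by this read-out. No measurement here accounts for that result.

Only these two groups at this one position can be compared, so an amine, a carboxylic acid or a longer chain such as butoxy could behave differently. Going by these compounds, whether chloro and methoxy also stand level on other positions of the shared core remains open.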